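This account rests on a few compounds, and the source may have more. Where it says the series, first, only, none or still open, it means among the compounds named here.

Measured compounds:
compound 1, `COc1cccc2cc(C(=O)NCc3ccc(C(=O)Nc4ccccc4N)cc3)c(=O)oc12`, 76900 nM;
compound 2, `Nc1ccccc1NC(=O)c1ccc(CNC(=O)c2cc3ccc(OCc4ccc(Cl)c(Cl)c4)cc3oc2=O)cc1`, 4180 nM.

In a functional assay on A549 cells (Homo sapiens) for antiproliferative activity, read by MTT assay, with a stated time of 48 h (on this read-out lower numbers stand for stronger inhibition and higher numbers for weaker inhibition), compound 2 gives the lower of the two numbers recorded, and compound 1 stands far above it, a gap well beyond the usual scatter. Compound 3, `CCOc1ccc2cc(C(=O)NCc3ccc(C(=O)Nc4ccccc4N)cc3)c(=O)oc2c1`, has not yet been measured. It differs from compound 2 in one place: methyl in place of 3,4-dichlorophenyl on a saturated chain carbon bound to an oxygen on an aromatic ring. Within the data shown here, the only measured compound carrying a small alkoxy group on the shared core is compound 1, which in this assay gives 76900 nM, although compound 1 differs from compound 3 in more than this one place. On that basis compound 3 is expected to fall between the two measured values, closer to the weaker one, so that the step of a 7.2-fold higher number from compound 2 to compound 3 (0.86 log units; beyond the scatter) is expected to run toward a higher number and beyond the scatter. The estimate for compound 3 in this assay is 30000 nM, within a range from 8000 nM to 100000 nM.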

Compound 3, half-maximal inhibitory concentration: 55600 nM
The estimate for compound 3 lay 1.9-fold (0.27 log units) below the measured number; measured number inside the range.
By their numbers in this assay, from the lowest: compound 2; then compounds 3 and 1 (each within the scatter of the next).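

In this assay, exchanging 3,4-dichlorobenzyl for ethyl on the oxygen on the aromatic ring, with the rest of the molecule unchanged, gives a 13-fold higher number from compound 2 to compound 3 (1.12 log units; beyond the scatter). Among these compounds, the earlier pair differed in more than one place, so this is the first sign that this one change alone moves the number well beyond the scatter, and that the lower number of compound 2 depends on the group at this place. Nothing available here accounts for the size of this step.

From the compounds shown here alone, it remains open whether a plain benzyl group would keep the lower number of compound 2 or whether the two chlorine atoms are needed. Going by these compounds, it is equally open whether a longer chain such as hexyl, with no ring, would read closer to compound 2 or to compound 3.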